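Swapping the Oxazole Aryl Group for a Morpholine Amide

The source may report more compounds than this note shows. Statements on the series, on what has been measured and on what is new or still open speak of the compounds shown alone.

Measured so far in an assay (Rattus norvegicus) for inhibition of Fatty-acid amide hydrolase 1 (Homo sapiens); a lower number here means a stronger inhibitor, a higher number a weaker inhibitor:
compound 1, `Nc1ccccc1-c1cnc(C(=O)CCCCCCc2ccccc2)o1`, 750 nM
compound 2, `Cc1cccnc1-c1cnc(C(=O)CCCCCCc2ccccc2)o1`, 15 nM
compound 3, `NC(=O)c1cccc(-c2cnc(C(=O)CCCCCCc3ccccc3)o2)n1`, 1 nM

Compound 3 gives the lowest number of the three, with compound 2 nearest and compound 1 furthest; both gaps lie beyond the scatter, so compound 3 is the strongest inhibitor of the set. Compound 4, `O=C(CCCCCCc1ccccc1)c1ncc(C(=O)N2CCOCC2)o1`, differs from compound 3 in one place: (morpholin-4-yl)carbonyl in place of 6-carbamoylpyridin-2-yl on an aromatic carbon. For the measured compounds named here, two measured steps bear on this position. The change a 750-fold lower number from compound 1 to compound 3 (2.88 log units; beyond the scatter) and the change a 15-fold lower number from compound 2 to compound 3 (1.18 log units; beyond the scatter) both show that what sits on this carbon of the shared core moves the number a great deal, and that the 6-carbamoylpyridin-2-yl group of compound 3 gives the best result seen. Going by the values given here, no measured compound carries a non-aromatic group there, so the size of the coming step is uncertain; a higher number than compound 3 is expected, though not as high as compound 1. The step of a 40-fold higher number from compound 3 to compound 4 (1.60 log units; beyond the scatter) is the estimate, and compound 4 is therefore expected to give about 40 nM in this assay, likely between 8 nM and 200 nM.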

Compound 4, inhibition constant: 24 nM
Compound 4: middle estimate off by 1.7-fold (0.22 log units), on the high side; measured number inside the range.
By their numbers in this assay, from the lowest: compound 3; then compounds 2 and 4 (each within the scatter of the next); then compound 1.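

Compound 4 shows that this aromatic carbon can hold a non-aromatic group and keep a low number in this assay: the (morpholin-4-yl)carbonyl group gives a 1.6-fold higher number from compound 2 to compound 4 (0.20 log units; within the scatter) against the 3-methylpyridin-2-yl group, and a 31-fold lower number from compound 1 to compound 4 (1.49 log units; beyond the scatter) against the 2-aminophenyl group. An aromatic ring on this carbon is therefore not required among these compounds, yet the 6-carbamoylpyridin-2-yl group stays clearly ahead, with a 24-fold higher number from compound 3 to compound 4 (1.38 log units; beyond the scatter) on replacing it. Nothing measured here accounts for these differences.

The compounds shown leave open whether a piperidine amide, a dimethylamide or a carboxylic acid on this carbon would give a number like that of compound 4. Also open, going by these compounds, is whether the (morpholin-4-yl)carbonyl group would hold its effect with a shorter chain on the ketone.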